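Thiophene in place of dichlorophenyl on the shared core

The source may hold more compounds than are shown below. What is called first, only, known or untested is meant among the compounds shown, and "the series" means these compounds.

Measured so far:
Compound 1, `Cc1ccc(C2C(C#N)=C(N)N(c3ccc(S(N)(=O)=O)cc3)C3=C2C(=O)CCC3)cc1`, gives 50 ug/mL in a functional assay on Ehrlich cells (Mus musculus) for antiproliferative activity, read by trypan blue exclusion, with a stated time of 2 h; a lower number here means a stronger inhibitor, a higher number a weaker inhibitor.
Compound 2, `N#CC1=C(N)N(c2ccc(S(N)(=O)=O)cc2)C2=C(C(=O)CCC2)C1c1ccc([N+](=O)[O-])cc1`, gives 2.5 ug/mL in this assay.
Compound 3, `N#CC1=C(N)N(c2ccc(S(N)(=O)=O)cc2)C2=C(C(=O)CCC2)C1c1ccc(Cl)cc1Cl`, gives 25 ug/mL in this assay.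

Compound 3 stands second highest of the three numbers: its nearest neighbour is compound 1, a 2.0-fold lower number from compound 1 to compound 3 (0.30 log units; within the scatter), while compound 2 lies furthest away, a 10-fold higher number from compound 2 to compound 3 (1.00 log units; beyond the scatter). The three compounds share one core and differ only in the aryl group on a saturated ring carbon. The step to compound 4, `N#CC1=C(N)N(c2ccc(S(N)(=O)=O)cc2)C2=C(C(=O)CCC2)C1c1cccs1`, is thiophen-2-yl in place of 2,4-dichlorophenyl on a saturated ring carbon.

Within the data shown here, two measured steps bear on it, both swaps of the same aryl group. The swap a 10-fold higher number from compound 2 to compound 3 (1.00 log units; beyond the scatter) was modest, whereas a 2.0-fold lower number from compound 1 to compound 3 (0.30 log units; within the scatter) stayed within the scatter. So the aryl group can move the number, but only the nitrophenyl has done so clearly. Among the measured compounds shown here, a thiophen-2-yl has no precedent here, so the expectation is a number near compounds 1 and 3, with wide uncertainty. Compound 4 is therefore expected at about 35 ug/mL, within 10 ug/mL to 100 ug/mL, an estimated step of a 1.4-fold higher number from compound 3 to compound 4 (0.15 log units; within the scatter).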

Compound 4, half-maximal inhibitory concentration: 5 ug/mL
Compound 4: middle estimate off by 7.0-fold (0.85 log units), on the high side; the whole stated range lies above it.
By their numbers in this assay, from the lowest: compounds 2 and 4 (each within the scatter of the next); then compounds 3 and 1 (each within the scatter of the next).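

In this assay the low number of compound 2 no longer belongs to the 4-nitrophenyl group alone: thiophen-2-yl on this saturated ring carbon gives a number within the scatter of it (a 2.0-fold higher number from compound 2 to compound 4 (0.30 log units; within the scatter)). The same group clears the scatter against both remaining aryl groups (a 5.0-fold lower number from compound 3 to compound 4 (0.70 log units; beyond the scatter); a 10-fold lower number from compound 1 to compound 4 (1.00 log units; beyond the scatter)). A nitro group is therefore not required for a low number at this position, and a five-membered aromatic ring with 1 hetero atom is accepted there in place of a six-membered aromatic ring of carbon only.

Going by these compounds, whether furan-2-yl, with oxygen in place of sulfur, or a cyclohexyl ring with no aromatic character would keep the number this low remains open. Nothing measured on these compounds accounts for the differences among them.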